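Phenyl in place of hydroxy on the chlorinated compound

The compounds below may be only part of what the source reports. "The series", "measured", "known", "first", "only" and "open" are said of these compounds alone.

Measured in a functional assay on SK-OV-3 cells (Homo sapiens) for inhibition, read by sulforhodamine B assay, with a stated time of 48 h; on this read-out lower numbers stand for stronger inhibition of growth and higher numbers for weaker inhibition of growth:
compound 1 `Cc1nnc(-c2nn(-c3ccccc3)c(-c3ccccc3)c2C#N)c2cn(-c3ccccc3)nc12`: 36800 nM
compound 2 `N#Cc1c(-c2nnc(O)c3nn(-c4ccccc4)cc23)nn(-c2ccccc2)c1-c1ccccc1`: 36800 nM
compound 3 `N#Cc1c(-c2nnc(O)c3nn(-c4ccc(Cl)cc4)cc23)nn(-c2ccccc2)c1-c1ccccc1`: 30800 nM

Compound 3 gives 30800 nM, within the scatter of compound 1 and compound 2, so the three values do not separate. Compound 4 `N#Cc1c(-c2nnc(-c3ccccc3)c3nn(-c4ccc(Cl)cc4)cc23)nn(-c2ccccc2)c1-c1ccccc1` carries phenyl in place of hydroxy on an aromatic carbon. Among the measured compounds shown here, two measured steps bear on this. Hydroxy in place of methyl at the same carbon gave no change at the digits printed from compound 1 to compound 2 (within the scatter), and chloro in place of hydrogen gave a 1.2-fold lower number from compound 2 to compound 3 (0.08 log units; within the scatter). No phenyl has been measured at this carbon, so the range stays wide. No change beyond the scatter is expected in this assay. The expected step is a 1.0-fold lower number from compound 3 to compound 4 (0.01 log units; within the scatter). Compound 4 is estimated at 30000 nM, with an expected range of 12000 nM to 65000 nM.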

Compound 4, concentration for 50% growth inhibition: > 100000 nM
Compound 4: no number, only a limit; the forecaster's own chance of this, stated with the estimate: 15%; middle value at least 3.3-fold (0.52 log units) from the limit.
By their numbers in this assay, from the lowest: compounds 3, 1 and 2 (each within the scatter of the next). At a limit, above all of these: compound 4.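

In this assay, among the compounds shown here, phenyl in place of hydroxy on this aromatic carbon gives an at least 3.2-fold higher number from compound 3 to compound 4 (0.51 log units; beyond the scatter), the only step that lies beyond the scatter. The carbon therefore does respond to a change of group, which the swap of hydroxy for methyl, no change at the digits printed from compound 1 to compound 2 (within the scatter), did not show. Compound 4 carries a limit of the assay, not a number: the limit of > 100000 nM in this assay, at which 1 of the 4 values shown sits.

On these data alone, the true size of the step stays unknown. Also open, as far as these compounds go, are whether an amine, a methoxy group or a carboxylic acid at this carbon keeps the growth inhibition, and whether phenyl acts alike without the chloro.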